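Extending the ether group on a hydroxyurea series

A few compounds are considered here, and "the series" means these few. Any claim that something is new, unique, unknown or untested is made for them only; others in the source may bear on it.

Measured so far:
Compound 1, `NC(=O)N(O)C1CCc2cc(OCc3ccccc3)ccc21` — 880 nM; 780 nM; 620 nM (3 entries)
Compound 2, `COc1ccc2c(c1)CCCC2N(O)C(N)=O` — 48000 nM
Compound 3, `NC(=O)N(O)C1CCCc2ccccc21` — 29000 nM

Compound 2 gives 48000 nM in an assay on isolated protein for inhibition of Polyunsaturated fatty acid 5-lipoxygenase (Rattus norvegicus) (on this read-out lower numbers stand for stronger inhibition and higher numbers for weaker inhibition), the highest of the two single numbers here. Its nearest neighbour is compound 3, and a 1.7-fold lower number from compound 2 to compound 3 (0.22 log units; within the scatter); this step, hydrogen in place of methoxy on an aromatic carbon, is within the scatter and so shows no real change. Compound 1 has several entries, (the several entries of compound 1 in this assay, 880 nM; 780 nM; 620 nM (3 entries)), all far lower than compound 2.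

The unmeasured compound 4, `NC(=O)N(O)C1CCCc2cc(OCc3ccc(Cl)cc3)ccc21`, differs from compound 2 by 4-chlorophenyl in place of hydrogen on a saturated chain carbon bound to an oxygen on an aromatic ring; cut one bond further out, the same difference reads methyl to 4-chlorobenzyl. Within the data shown here, no measured step covers this change directly. Among the measured compounds shown here, the only step on the shared core, from compound 2 to compound 3, is small and concerns the methoxy group alone, so it says little about adding a 4-chlorophenyl group. Compound 4 has a close relative on a slightly different core, and that relative, compound 1, gives 880 nM; 780 nM; 620 nM (3 entries). This suggests a much lower number for compound 4. Compound 4 is therefore expected to give 700 nM in this assay, between 150 nM and 3500 nM, an expected step of a 69-fold lower number from compound 2 to compound 4 (1.84 log units; beyond the scatter).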

Compound 4, half-maximal inhibitory concentration: 2200 nM
Beside the measured number, compound 4's estimate is 3.1-fold (0.50 log units) below it; measured number inside the range.
By their numbers in this assay, from the lowest: compound 4; then compounds 3 and 2 (each within the scatter of the next).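

In this assay, among these compounds, the only earlier step on the shared core, a 1.7-fold lower number from compound 2 to compound 3 (0.22 log units; within the scatter), showed no real change when the methoxy group was replaced by hydrogen, so this position could have seemed indifferent to what sits there. The new result, a 22-fold lower number from compound 2 to compound 4 (1.34 log units; beyond the scatter), shows that it is not: the number falls clearly when methyl on the ether oxygen gives way to 4-chlorobenzyl, with 4-chlorophenyl entering on the saturated chain carbon bound to an oxygen on an aromatic ring. Since the methoxy compound and the compound without any ether lie within the scatter of each other, a real drop on this core appears only with the larger group.

Going by these compounds, it stays open how much of the drop belongs to the chlorine, as the benzyl ether on the core of compound 1 differs from compound 4 in more than one place and so cannot settle this: the several entries of compound 1 in this assay, 880 nM; 780 nM; 620 nM (3 entries). Also open, on these data alone, is whether a plain benzyl group on the shared core, a longer chain such as 2-phenylethyl, or an amine at the end of the ether chain would give a similar number.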